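Where a Sulfo Group Sits Decides Binding

This account rests on a few compounds, and the source may have more. Where it says the series, first, only, none or still open, it means among the compounds named here.

Compound 1 `CC(=O)N[C@H]1[C@@H](OC[C@@H](O)[C@@H](O)[C@H](O)[C@@H](O)CNc2cccc(NC(=O)CCCCC3CCSS3)c2)O[C@H](CO)[C@H](O)[C@@H]1O[C@@H]1O[C@H](C(=O)O)[C@@H](O)[C@H](O)[C@H]1O` stands without a number: in an assay on isolated protein for binding affinity to fibroblast growth factor 2 (Homo sapiens), read by surface plasmon resonance (a lower number here means tighter binding, a higher number weaker binding), compound 1 is recorded as "not active" (no number reported). Compound 2 `CC(=O)N[C@H]1[C@@H](OC[C@@H](O)[C@@H](O)[C@H](O)[C@@H](O)CNc2cccc(NC(=O)CCCCC3CCSS3)c2)O[C@H](COS(=O)(=O)O)[C@H](O)[C@@H]1O[C@@H]1O[C@H](C(=O)O)[C@@H](O)[C@H](O)[C@H]1O`, which also carries a sulfo group, gives 36 nM in this assay. Compound 3 `CC(=O)N[C@H]1[C@@H](OC[C@@H](O)[C@@H](O)[C@H](O)[C@@H](O)CNc2cccc(NC(=O)CCCCC3CCSS3)c2)O[C@H](CO)[C@H](O)[C@@H]1O[C@@H]1O[C@H](C(=O)O)[C@@H](O)[C@H](OS(=O)(=O)O)[C@H]1O` is reached from compound 1 by the change (sulfo in place of hydrogen on an oxygen on a saturated carbon), sulfo in place of hydrogen on an oxygen on a saturated carbon. Within the data shown here, no measured step joins compounds 1 and 3, so the expectation rests on compound 1 showing no measurable binding while compound 2 shows a number in this assay; a step toward tighter binding, beyond the scatter, is expected. Compound 3 is estimated at 300 nM, within 40 nM to 5000 nM.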

Compound 3, dissociation constant: 25 nM
Beside the measured number, compound 3's estimate is 12-fold (1.08 log units) above it; the whole stated range lies above it.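

Among these compounds, compound 1 has no number, so no step from it to compound 3 can be read. The compounds shown leave open how much binding the sulfooxy group adds to the shared core, and no measurement shown explains the result.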